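The source may report more compounds than this note shows. Statements on the series, on what has been measured and on what is new or still open speak of the compounds shown alone.

Measured so far:
compound 1 `C[C@H](Nc1c(C(N)=O)nnc2ccc(-c3ccc(OCCCN(C)C)nc3)cc12)c1ccn(C)n1` – 1.7
compound 2 `Cc1cn(C)nc1[C@H](C)Nc1c(C(N)=O)nnc2ccc(-c3ccc(OCCCN(C)C)nc3)cc12` – 2.1

In a physicochemical assay for lipophilicity, using the shake flask method, measured as octanol-water partition, with a stated time of 30 min, at pH 7.4 (on this read-out higher numbers stand for higher lipophilicity and lower numbers for lower lipophilicity), compound 1 stands lowest of the two numbers; its nearest neighbour is compound 2, reached by a number 0.40 log units higher from compound 1 to compound 2 (beyond the scatter). Compound 3 `C[C@H](Nc1c(C(N)=O)nnc2ccc(-c3ccc(OCCCN4CCCC4)nc3)cc12)c1ccn(C)n1` differs from compound 1 by pyrrolidin-1-yl in place of dimethylamino on a saturated chain carbon, three bonds along the chain from an oxygen on an aromatic ring. Going by the values given here, no measured step covers this exchange; the only step on hand, a number 0.40 log units higher from compound 1 to compound 2 (beyond the scatter), concerns a different place and adds fewer heavy atoms than the present change. By analogy to that step, a modest rise in this assay is expected, read as a number 0.40 log units higher from compound 1 to compound 3 (beyond the scatter). For compound 3 the estimate in this assay is 2.1, within 1.7 to 2.5.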

Compound 3, distribution coefficient: 1.8
For compound 3 the middle estimate is 0.30 log units above the measured one; measured number inside the range.
By their numbers in this assay, from the lowest: compounds 1, 3 and 2 (each within the scatter of the next, the first and the last beyond it).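

In this assay the exchange of 3-(dimethylamino)propyl for 3-(pyrrolidin-1-yl)propyl gives a number 0.10 log units higher from compound 1 to compound 3 (within the scatter) and so stays within the scatter. On a saturated chain carbon, three bonds along the chain from an oxygen on an aromatic ring, a five-membered ring and more heavy atoms thus bring no step beyond the scatter, unlike a number 0.40 log units higher from compound 1 to compound 2 (beyond the scatter) at a different place. No supporting measurement bears on this result.

Open, from the compounds shown here alone, is whether piperidin-1-yl, morpholin-4-yl or a longer chain would read the same here. Also open, going by these compounds, is how pyrrolidin-1-yl behaves alongside the added methyl of compound 2.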